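A few compounds are considered here, and "the series" means these few. Any claim that something is new, unique, unknown or untested is made for them only; others in the source may bear on it.

Compound 3 `CCn1ncc2c(F)cc(-c3ccc(C(CC)(CC)c4nnc(C)[nH]4)c(=O)[nH]3)cc21` gives the highest number of the three measured compounds in a functional assay on CHO cells for antagonist activity at prostaglandin E2 receptor EP3 subtype (Homo sapiens), read by cAMP accumulation (a lower number here means a stronger inhibitor, a higher number a weaker inhibitor), at 90 nM. Going by the values given here, compound 1 `CC(C)C(c1ncc[nH]1)c1ccc(-c2ccc3cccc(F)c3c2)[nH]c1=O` gives 33 nM, and compound 2 `CC(C)C(c1nnc[nH]1)c1ccc(-c2ccc3cccc(F)c3c2)[nH]c1=O` gives 21 nM; the only one-place step among them, a 1.6-fold lower number from compound 1 to compound 2 (0.20 log units; within the scatter), lies within the scatter. Compound 4 `CCn1ncc2c(F)cc(-c3ccc(C(CC)(CC)c4nnc[nH]4)c(=O)[nH]3)cc21` differs from compound 3 in a single place: hydrogen in place of methyl on an aromatic carbon. Among the compounds with values here, no measured step removes a methyl from the five-membered aromatic ring with 3 nitrogen, so the change from compound 1 to compound 2 offers only indirect guidance, and nothing in the measured steps points to a shift beyond the scatter. Compound 4 is therefore expected to give about 80 nM (range 30 nM to 220 nM), a step of a 1.1-fold lower number from compound 3 to compound 4 (0.05 log units; within the scatter) in this assay.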

Compound 4, half-maximal inhibitory concentration in the prostaglandin E2 receptor EP3 subtype assay: 29 nM
Estimate against measurement, compound 4: 2.8-fold (0.44 log units) above, outside the stated range (below it).
By their numbers in the prostaglandin E2 receptor EP3 subtype assay, from the lowest: compounds 2, 4 and 1 (each within the scatter of the next); then compound 3.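

Going by these compounds alone, in the prostaglandin E2 receptor EP3 subtype assay, hydrogen in place of methyl on an aromatic carbon of the five-membered aromatic ring with 3 nitrogen gives a 3.1-fold lower number from compound 3 to compound 4 (0.49 log units; beyond the scatter), the only one-place step here beyond the scatter, so the group on this carbon can shift the number. In a physicochemical assay for solubility, in phosphate buffer, measured as kinetic solubility (on this read-out higher numbers stand for higher solubility and lower numbers for lower solubility), compound 3 gives 26900 nM and compound 4 gives 35500 nM, with a 1.3-fold higher number from compound 3 to compound 4 (0.12 log units; within the scatter). Nothing available gives a cause for the step in the first of these read-outs.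

From the compounds shown here alone, how ethyl, trifluoromethyl or an amine on this carbon would read stays open. So does whether methyl on this carbon would shift the number on the core of compound 2 to the same extent.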